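The compounds below may be only part of what the source reports. "The series", "measured", "known", "first", "only" and "open" are said of these compounds alone.

Measured so far:
compound 1 `COc1cc(/C=C/C(=O)Nc2cc3c(Nc4ccc(F)c(Cl)c4)ncnc3cc2O[C@H]2CCOC2)cc(OC)c1O` — 27000 nM in a functional assay on A549 cells (Homo sapiens) for cytotoxicity, read by MTT assay, with a stated time of 72 h; on this read-out lower numbers stand for stronger inhibition and higher numbers for weaker inhibition
compound 2 `O=C(/C=C/c1cccc(Cl)c1Cl)Nc1cc2c(Nc3ccc(F)c(Cl)c3)ncnc2cc1O[C@H]1CCOC1` — 23200 nM in this assay

Only these two compounds have been run, and compound 1 and compound 2 sit within the usual scatter of each other: the step of a 1.2-fold lower number from compound 1 to compound 2 (0.07 log units; within the scatter) is too small to read as a real difference. Both aryl variants on the double-bonded chain give weak inhibition of the same order, so compound 1 stands with compound 2 at the weak end of what the shared core has shown so far.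

Compound 3 `O=C(/C=C/c1cc(Br)c(O)c(Br)c1)Nc1cc2c(Nc3ccc(F)c(Cl)c3)ncnc2cc1O[C@H]1CCOC1` keeps the core of compound 1 and changes only the aryl group: 3,5-dibromo-4-hydroxyphenyl in place of 4-hydroxy-3,5-dimethoxyphenyl on a double-bonded chain carbon bound to a double-bonded chain carbon.

Among the measured compounds shown here, the single measured step that bears on an aryl swap at this position is a 1.2-fold lower number from compound 1 to compound 2 (0.07 log units; within the scatter), which is within the scatter even though the group changes from an oxygen-rich hydroxy-dimethoxy ring to a dichlorinated ring. The series therefore gives no sign that this position moves the read-out in this assay beyond the scatter, and no step in either direction is expected; the estimate for compound 3 in this assay is 25000 nM, range 10000 nM to 60000 nM, which means an expected step of a 1.1-fold lower number from compound 1 to compound 3 (0.03 log units; within the scatter).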

Compound 3, half-maximal inhibitory concentration: 28800 nM
Compound 3: the middle estimate sits 1.2-fold (0.06 log units) below what was measured; measured number inside the range.
By their numbers in this assay, from the lowest: compounds 2, 1 and 3 (each within the scatter of the next).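

In this assay, a 1.1-fold higher number from compound 1 to compound 3 (0.03 log units; within the scatter) and a 1.2-fold higher number from compound 2 to compound 3 (0.09 log units; within the scatter) both lie within the scatter, so three aryl groups on a double-bonded chain carbon bound to a double-bonded chain carbon now give numbers that cannot be told apart. Compound 3 also adds a narrower comparison than the earlier pair allowed: its 3,5-dibromo-4-hydroxyphenyl group keeps the hydroxy group of the 4-hydroxy-3,5-dimethoxyphenyl group in compound 1 and carries bromine where compound 1 carries methoxy, and this exchange leaves the read-out within the scatter as well. Nothing at hand explains why the read-out stays flat across these aryl groups.

As far as these compounds go, all three compounds carry a substituted phenyl group at this position, so the flat read-out describes that group type only, and whether a pyridine ring, a dimethylamino group or a carboxylic acid there would move the number beyond the scatter remains open. Also open, from the compounds shown here alone, is whether this position stays as flat once the shared core is changed, for example with another group in place of the 3-chloro-4-fluoroaniline part.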